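Anilide tail variation on the nitrobenzofurazan thioether series

This account rests on a few compounds, and the source may have more. Where it says the series, first, only, none or still open, it means among the compounds named here.

In a functional assay on A549 cells (Homo sapiens) for inhibition, read by MTT assay, with a stated time of 72 h (a lower number here means a stronger inhibitor, a higher number a weaker inhibitor), the acid compound 1 `O=C(O)CCC(=O)OCCCCCCSc1ccc([N+](=O)[O-])c2nonc12` gives 3640 nM, the fluoroanilide compound 2 `O=C(CCC(=O)OCCCCCCSc1ccc([N+](=O)[O-])c2nonc12)Nc1ccc(F)cc1` gives 6300 nM, and the methylanilide compound 3 `Cc1ccc(NC(=O)CCC(=O)OCCCCCCSc2ccc([N+](=O)[O-])c3nonc23)cc1` gives 5240 nM. Compound 3 sits among three numbers that all lie close together: a 1.4-fold higher number from compound 1 to compound 3 (0.16 log units; within the scatter) and a 1.2-fold lower number from compound 2 to compound 3 (0.08 log units; within the scatter), so nothing here separates the three beyond the scatter. Compound 4 `COc1ccc(NC(=O)CCC(=O)OCCCCCCSc2ccc([N+](=O)[O-])c3nonc23)cc1` differs from compound 3 only by methoxy in place of methyl on an aromatic carbon. For the measured compounds named here, the nearest precedent is the exchange on the same aromatic carbon, a 1.2-fold lower number from compound 2 to compound 3 (0.08 log units; within the scatter), and the larger change from acid to anilide, a 1.7-fold higher number from compound 1 to compound 2 (0.24 log units; within the scatter), also stayed within the scatter. The expected step of a 1.0-fold higher number from compound 3 to compound 4 (0.02 log units; within the scatter) is therefore no change beyond the scatter. Compound 4 is estimated at 5500 nM, with a range from 2500 nM to 12000 nM.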

Compound 4, half-maximal inhibitory concentration: 6480 nM
For compound 4 the middle estimate is 1.2-fold (0.07 log units) below the measured one; measured number inside the range.
By their numbers in this assay, from the lowest: compounds 1, 3, 2 and 4 (each within the scatter of the next).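

Methoxy brings a hydrogen-bond acceptor to the aromatic carbon para to a large group, yet in this assay the exchange for methyl gives a 1.2-fold higher number from compound 3 to compound 4 (0.09 log units; within the scatter) and the exchange for fluoro gives a 1.0-fold higher number from compound 2 to compound 4 (0.01 log units; within the scatter) and so leaves methyl, fluoro and methoxy unseparated at this position. The methoxyanilide also stays within the scatter of the acid, with a 1.8-fold higher number from compound 1 to compound 4 (0.25 log units; within the scatter) as its step. No supporting data bear on why this position shows so little response.

Open, on these data alone, is whether an amine or a carboxylic acid on this aromatic carbon, or a longer chain in the tail, would shift the number beyond the scatter.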